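This account rests on a few compounds, and the source may have more. Where it says the series, first, only, none or still open, it means among the compounds named here.

Working notes on the sulfonamide series in a functional assay on A549 cells (Homo sapiens) for inhibition; a lower number here means a stronger inhibitor of growth, a higher number a weaker inhibitor of growth.

Of the compounds shown here, two have been measured. Compound 1 `O=S(=O)(Nc1ccccc1)c1ccc(I)cc1` gives 23000 nM in this assay. Compound 2 `CC(C)(C)c1ccc(S(=O)(=O)Nc2ccccc2)cc1` gives 16000 nM in this assay. The one step between them, a 1.4-fold lower number from compound 1 to compound 2 (0.16 log units; within the scatter), is within the scatter, so the two numbers cannot be told apart; compound 2 stands together with compound 1 at the only level the series has shown so far.

The next compound, compound 3 `O=S(=O)(Nc1ccccc1)c1ccc(-c2ccccc2)cc1`, differs from compound 2 in one place: phenyl in place of tert-butyl on an aromatic carbon. For the measured compounds named here, only one measured step bears on this position, the exchange at the same aromatic carbon from compound 1 to compound 2, and that step was within the scatter. Going by the values given here, nothing in the measured pairs indicates that a change at this position moves the number, and no measured pair shows a phenyl at this position. The expectation for this assay is therefore no step beyond the scatter, a 1.1-fold lower number from compound 2 to compound 3 (0.03 log units; within the scatter). Compound 3 is expected to give about 15000 nM in this assay, with a range from 5000 nM to 45000 nM.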

Compound 3, concentration for 50% growth inhibition: 17000 nM
The estimate for compound 3 lay 1.1-fold (0.05 log units) below the measured number; the measured number falls inside the stated range.
By their numbers in this assay, from the lowest: compounds 2, 3 and 1 (each within the scatter of the next).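

In this assay, phenyl in place of tert-butyl on an aromatic carbon gives a 1.1-fold higher number from compound 2 to compound 3 (0.03 log units; within the scatter), and phenyl in place of iodo at the same carbon gives a 1.4-fold lower number from compound 1 to compound 3 (0.13 log units; within the scatter). With a ring now tested at this position, all three groups, iodo, tert-butyl and phenyl, stand at one level, so exchanging a single atom, a branched alkyl group or a six-membered aromatic ring of carbon only has not separated any of the compounds here; this holds for these three compounds only. No supporting information bears on why the numbers stay together.

Going by these compounds, all three groups at this position carry no hydrogen-bond donors or acceptors and no net charge, so it remains open whether an amine, a carboxylic acid or a methoxy group on the same aromatic carbon would move the number beyond the scatter. On these data alone, it is also open whether a change elsewhere on the shared core, such as a substituent on the other ring or at the sulfonamide nitrogen, would do so.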